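The source may report more compounds than this note shows. Statements on the series, on what has been measured and on what is new or still open speak of the compounds shown alone.

Working notes on the series in an ADME assay on MDBK cells (Bos taurus) for cytotoxicity; on this read-out higher numbers stand for lower toxicity in this test and lower numbers for higher toxicity in this test.

Compound 1 `COc1ccccc1Cn1ccc2nc(-c3ccccc3)nc-2c1` carries a methoxy on an aromatic carbon. In this assay compound 1 gives > 100000 nM, which is a limit of the assay and not a number. Compound 2 `N#Cc1ccccc1Cn1ccc2nc(-c3ccccc3)nc-2c1` differs in that place, with cyano in place of methoxy on an aromatic carbon. In this assay compound 2 gives > 100000 nM, again a limit of the assay rather than a number. The step that the two limits leave unreadable from compound 1 to compound 2 is therefore not readable in size or direction, since both values sit at the limit of > 100000 nM in this assay, at which 2 of the 2 values shown sit.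

Compound 3 `CC(C)=CCn1ccc2nc(-c3ccccc3)nc-2c1` is the next member to be measured. Its change from compound 2 is 2-methylprop-1-en-1-yl in place of 2-cyanophenyl on a saturated chain carbon bound to an aromatic nitrogen. For the measured compounds named here, the only measured step, from compound 1 to compound 2, sits entirely at the limit and gives no scale for the effect of exchanging the group on the chain carbon bound to the aromatic nitrogen. With both measured compounds at the limit, the expectation for compound 3 is that it stays near that limit, with the step of a number no higher from compound 2 to compound 3 (the limit leaves the size open) expected to be no more than the scatter allows. Compound 3 is estimated at 100000 nM, with a range from 25000 nM to 300000 nM, and it is likely that the assay again reports only a limit.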

Compound 3, half-maximal cytotoxic concentration: > 100000 nM
Compound 3: a limit, no number; the forecaster's own chance of this, stated with the estimate: 70%; the middle value lies on the limit itself.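

Compound 3 gives > 100000 nM in this assay, again a limit and not a number. No step among compound 1, compound 2 and compound 3 can be read, since all three sit at the same limit: the limit of > 100000 nM in this assay, at which 3 of the 3 values shown sit.

The compounds shown leave open whether the group on the saturated chain carbon bound to an aromatic nitrogen affects the read-out in this assay at all.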